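From Bromo to Trifluoromethyl on a Phenyl Group

The compounds below may be only part of what the source reports. "The series", "measured", "known", "first", "only" and "open" are said of these compounds alone.

Of the compounds shown here, two that share one core have been measured so far. In a functional assay on MCF7 cells (Homo sapiens) for inhibition, read by sulforhodamine B assay (on this read-out higher numbers stand for weaker inhibition and lower numbers for stronger inhibition), compound 1 `O=C1C=C(Nc2ccccc2F)C(=O)c2c1nc1n2[C@H]2OC[C@@H](O)[C@H]2OC1` gives 3640 nM, and compound 2 `O=C1C=C(Nc2ccc(Br)cc2)C(=O)c2c1nc1n2[C@H]2OC[C@@H](O)[C@H]2OC1` gives 2580 nM. These two numbers sit within the usual scatter of repeated measurements, so neither compound can be ranked ahead of the other, and compound 2 stands level with compound 1.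

Compound 3 `O=C1C=C(Nc2ccc(C(F)(F)F)cc2)C(=O)c2c1nc1n2[C@H]2OC[C@@H](O)[C@H]2OC1` has not been measured yet. It differs from compound 2 by a single exchange, trifluoromethyl in place of bromo on an aromatic carbon. Among the measured compounds shown here, no measured step covers this exact exchange, so the evidence is thin. For the measured compounds named here, the one step that bears on it is a swap of the phenyl group on the amine nitrogen, a 1.4-fold lower number from compound 1 to compound 2 (0.15 log units; within the scatter). That swap stayed within the scatter, so no step beyond the scatter is expected in this assay, in either direction. The expected move is a 1.1-fold higher number from compound 2 to compound 3 (0.04 log units; within the scatter). For compound 3 the estimated value is 2800 nM, with an expected range from 1300 nM to 6000 nM.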

Compound 3, half-maximal inhibitory concentration: > 4000 nM
Compound 3 gave a limit, no number (the forecaster's own chance of this, stated with the estimate: 3%); middle value at least 1.4-fold (0.15 log units) from the limit.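

In this assay compound 3 gives > 4000 nM, which is a limit of the assay and not a number. Trifluoromethyl in place of bromo on this aromatic carbon therefore reads only as a floor, an at least 1.5-fold higher number from compound 2 to compound 3 (0.19 log units; that floor lies within the scatter), and the swap of the whole phenyl group reads the same way, an at least 1.0-fold higher number from compound 1 to compound 3 (0.04 log units; that floor lies within the scatter). Unlike the step between the two earlier compounds, these steps have no upper end, so the change could be small or large, and since both floors stay within the scatter, compound 3 cannot yet be ranked against either neighbour, with the series now touching the ceiling of the assay at a single compound: the limit of > 4000 nM in this assay, at which 1 of the 3 values shown sits.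

The compounds shown leave open where the true value of compound 3 lies, and so whether trifluoromethyl and bromo differ at all at this place on the phenyl group. They also leave open what a group of another kind would do on the same aromatic carbon, such as an amine, a carboxylic acid or a methoxy group.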